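The source may hold more compounds than are shown below. What is called first, only, known or untested is meant among the compounds shown, and "the series" means these compounds.

Going by the values given here, compound 3 `CS(=O)(=O)Oc1c(C(=O)NCc2ccc(F)cc2)nc(Br)c2cccnc12` is one of three compounds measured in a functional assay on HCT-116 cells (Homo sapiens) for cytotoxicity, read by MTT assay, with a stated time of 72 h; a higher number here means a weaker inhibitor, a lower number a stronger inhibitor. In this assay compound 3 gives only a limit, > 20000 nM. Compound 2 `O=C(NCc1ccc(F)cc1)c1nc(Br)c2cccnc2c1NCCCNc1c(C(=O)NCc2ccc(F)cc2)nc(Br)c2cccnc12` also gives only a limit in this assay, > 20000 nM. Compound 1 `COc1cccc(CNC(=O)c2nc(Br)c3cccnc3c2N[C@H]2CC[C@H](N)CC2)c1` gives 6000 nM in this assay. Compound 3 therefore stands at the limit of > 20000 nM in this assay, at which 2 of the 3 values shown sit, with no number of its own. Compound 4 `COC(=O)CNc1c(C(=O)NCc2ccc(F)cc2)nc(Br)c2cccnc12` differs from compound 3 by ((methoxycarbonyl)methyl)amino in place of (methylsulfonyl)oxy on an aromatic carbon. Among the compounds with values here, no step between measured compounds is available, so the size of this change is open; a gain in potency beyond the scatter is expected, since compound 1, which also carries an amino substituent, gives 6000 nM. The expected step is an at least 1.6-fold lower number from compound 3 to compound 4 (0.22 log units; that floor lies within the scatter). Compound 4 is estimated at 12000 nM, between 3000 nM and 50000 nM.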

Compound 4, half-maximal inhibitory concentration: > 10000 nM
Compound 4: only a limit was reported; the forecaster's own chance of this, stated with the estimate: 40%; the middle value does not contradict the limit.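

Going by these compounds alone, compound 3 and compound 4 each give only a limit, so no step between them can be read. The compounds shown leave open whether ((methoxycarbonyl)methyl)amino in place of (methylsulfonyl)oxy changes potency at all.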